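Diethylamino in place of 4-methylpiperazin-1-yl in compound 2

This account rests on a few compounds, and the source may have more. Where it says the series, first, only, none or still open, it means among the compounds named here.

Of the compounds shown here, two have so far been read in a functional assay on the whole organism with Mus musculus as the target, in the rotarod test; a higher number here means that more compound is needed for the effect, a lower number that less compound is needed. Compound 1 (`NCC(=O)NCC(=O)Nc1ccc([N+](=O)[O-])cc1C(=O)c1ccccc1`) gives 24.8 mg/kg. Compound 2 (`CN1CCN(CC(=O)NCC(=O)N(C)c2ccc(Cl)cc2C(=O)c2ccccc2Cl)CC1`) gives > 100 mg/kg, which is a limit of the assay and not a number. For the measured compounds named here, the pair differs in more than one place, so no single-change step is available to guide the next reading. Compound 3 (`CCN(CC)CC(=O)NCC(=O)N(C)c1ccc(Cl)cc1C(=O)c1ccccc1Cl`) keeps the rest of compound 2 and carries diethylamino in place of 4-methylpiperazin-1-yl on a saturated chain carbon bound to a carbonyl carbon. Going by the values given here, the only numerical guide in this assay is compound 1 at 24.8 mg/kg. The expected change is an at least 1.6-fold lower number from compound 2 to compound 3 (0.22 log units; that floor lies within the scatter), towards less compound needed, although another limit reading remains possible. For compound 3 the estimated value is 60 mg/kg, with an expected range of 18 mg/kg to 200 mg/kg.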

Compound 3, dose for half-maximal effect: 34 mg/kg
Compound 3: middle estimate off by 1.8-fold (0.25 log units), on the high side; measured number inside the range.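

In this assay, for the compounds shown here, diethylamino in place of 4-methylpiperazin-1-yl on a saturated chain carbon bound to a carbonyl carbon gives an at least 2.9-fold lower number from compound 2 to compound 3 (0.46 log units; beyond the scatter), the first single change seen to move the reading, towards less compound needed. With the rest of compound 2 held, the amine at this position therefore matters: diethylamino gives a number where 4-methylpiperazin-1-yl gives only a limit. The step is a floor and not a full size, because compound 2 stands at a limit of the assay and not at a number: the limit of > 100 mg/kg in this assay, at which 1 of the 3 values shown sits.

Open, going by these compounds, is whether the ring or the second nitrogen of 4-methylpiperazin-1-yl carries the difference; piperidin-1-yl at this position would separate the two. Also open, on these data alone, is how the reading follows the chains on this amine, with dimethylamino or dipropylamino as the neighbouring points.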